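The source may report more compounds than this note shows. Statements on the series, on what has been measured and on what is new or still open speak of the compounds shown alone.

Compound 1 `Cn1ncc2c(NC(=O)NCc3cc(C(F)(F)F)nn3-c3cccc(Cl)c3)cccc21`: 2.3 nM
Compound 2 `Cn1ncc2c(NC(=O)NCc3cc(C(F)(F)F)nn3-c3ccc(C(F)(F)F)cc3)cccc21`: 3.9 nM
Compound 3 `Cn1ncc2c(NC(=O)NCc3cc(C(F)(F)F)nn3-c3ccc(F)c(F)c3)cccc21`: 4.9 nM

The three measured compounds share one core and differ only in the aryl group on the ring nitrogen. In an assay on CHO-K1 cells for antagonist activity at transient receptor potential cation channel subfamily V member 1 (Homo sapiens), read by FLIPR and calcium flux, with a stated time of 6 min (a lower number here means a stronger inhibitor, a higher number a weaker inhibitor), compound 3 gives 4.9 nM, the highest number of the three; the step of a 1.3-fold higher number from compound 2 to compound 3 (0.10 log units; within the scatter) lies within the scatter, while a 2.1-fold higher number from compound 1 to compound 3 (0.33 log units; beyond the scatter) lies beyond it. Compound 4 `Cn1ncc2c(NC(=O)NCc3cc(C(C)(C)C)nn3-c3ccc(F)c(F)c3)cccc21` takes a different route: tert-butyl in place of trifluoromethyl on an aromatic carbon. Among the compounds with values here, none of the measured steps changes this position, so there is no direct guide to its size. The expected step of a 1.6-fold higher number from compound 3 to compound 4 (0.21 log units; within the scatter) is therefore small and uncertain in direction. Compound 4 is estimated at 8 nM, with a range from 2 nM to 30 nM.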

Compound 4, inhibition constant: 1 nM
For compound 4 the middle estimate is 8.0-fold (0.90 log units) above the measured one, and the stated range ends above it.
By their numbers in this assay, from the lowest: compound 4; then compounds 1, 2 and 3 (each within the scatter of the next, the first and the last beyond it).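

Until now only the aryl group on the ring nitrogen had changed. Swapping trifluoromethyl for tert-butyl on the five-membered ring gives a 4.9-fold lower number from compound 3 to compound 4 (0.69 log units; beyond the scatter) in this assay, so this carbon position also affects the number, and by more than the scatter. Trifluoromethyl is therefore not required here for a low number, at least alongside the 3,4-difluorophenyl group, but no measurement shown accounts for the change.

Going by these compounds, whether smaller groups at this carbon, such as methyl or cyclopropyl, or an amine, would serve as well remains open. So does whether tert-butyl would lower the number with the 3-chlorophenyl group of compound 1.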